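The compounds below may be only part of what the source reports. "The series", "measured", "known", "first", "only" and "open" are said of these compounds alone.

Among the compounds with values here, compound 2 `CS(=O)(=O)C[C@H](NC(=O)c1ccc(C#Cc2ccccc2)cc1)C(=O)NO` is one of two compounds measured in a physicochemical assay for lipophilicity; on this read-out lower numbers stand for lower lipophilicity and higher numbers for higher lipophilicity. In this assay compound 2 gives 2, the lowest of the two numbers. Within the data shown here, its nearest neighbour is compound 1 `C#CCNC(=O)C[C@H](NC(=O)c1ccc(C#Cc2ccccc2)cc1)C(=O)NO`, which in this assay gives 3; the only measured step, a number 1.00 log units lower from compound 1 to compound 2 (beyond the scatter), is a modest one that lies beyond the scatter.

The next compound, compound 3 `O=C(CNC(=O)c1ccc(C#Cc2ccccc2)cc1)NO`, has not yet been measured. It differs from compound 2 in one place: hydrogen in place of (methylsulfonyl)methyl on a saturated chain carbon bound to an amide-type nitrogen and a carbonyl carbon. Among the measured compounds shown here, no measured step removes this group entirely, so the step from compound 1 to compound 2 is only a loose guide: it swapped one substituent for another at the same chain carbon and gave a modest shift in this assay. Taking away the (methylsulfonyl)methyl group altogether, with a hydrogen entering, is a different kind of change, so the expected shift is small and uncertain, most likely upward.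

On this basis compound 3 is expected to give about 2.6 in this assay, within a range of roughly 2.1 to 3.1. The estimated step, a number 0.60 log units higher from compound 2 to compound 3 (beyond the scatter), is modest and near the edge of the scatter.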

Compound 3, distribution coefficient: 3
Compound 3: the middle estimate sits 0.40 log units below what was measured; measured number inside the range.
By their numbers in this assay, from the lowest: compound 2; then compounds 1 and 3 (each within the scatter of the next).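

Compound 3 carries only a hydrogen on the saturated chain carbon bound to an amide-type nitrogen and a carbonyl carbon, and so gives this position a reference point that the earlier pair lacked. In this assay, replacing (methylsulfonyl)methyl with hydrogen gives a number 1.00 log units higher from compound 2 to compound 3 (beyond the scatter), whereas replacing (propargylcarbamoyl)methyl with hydrogen gives no change at the digits printed from compound 1 to compound 3 (within the scatter), so the read-out at this position depends on which group leaves: of the two substituted compounds, only compound 2 stands apart from the compound with hydrogen, and compound 1 stays within the scatter of it. No supporting measurement explains this difference between the two groups.

The compounds shown leave open how a plain methyl, a longer alkyl chain, an amine or a carboxylic acid on this same carbon would read in this assay. They also leave open which part of the (methylsulfonyl)methyl group goes with the lower number, and a methylthio-bearing chain or a sulfonamide at this carbon would be a natural comparison for that question.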